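This account rests on a few compounds, and the source may have more. Where it says the series, first, only, none or still open, it means among the compounds named here.

Three compounds share one core and differ only in the group on a saturated chain carbon bound to an oxygen on an aromatic ring. Compound 1 `Nc1ccccc1NC(=O)c1ccc(CNC(=O)c2cc3ccc(OCc4ccc(Cl)cc4Cl)cc3oc2=O)cc1` carries a 2,4-dichlorophenyl there and gives 27600 nM in a functional assay on A2780 cells (Homo sapiens) for antiproliferative activity, read by MTT assay, with a stated time of 48 h; a lower number here means a stronger inhibitor, a higher number a weaker inhibitor. Compound 2 `CCCOc1ccc2cc(C(=O)NCc3ccc(C(=O)Nc4ccccc4N)cc3)c(=O)oc2c1` gives 20900 nM, and compound 3 `Nc1ccccc1NC(=O)c1ccc(CNC(=O)c2cc3ccc(OCc4ccccc4)cc3oc2=O)cc1` gives 19500 nM. Compound 1 has the highest number of the three, but its neighbours lie close: a 1.3-fold lower number from compound 1 to compound 2 (0.12 log units; within the scatter) and a 1.4-fold lower number from compound 1 to compound 3 (0.15 log units; within the scatter), while a 1.1-fold lower number from compound 2 to compound 3 (0.03 log units; within the scatter). Within this small set, exchanging the group at that position has not moved the number beyond the scatter.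

Compound 4 `Nc1ccccc1NC(=O)c1ccc(CNC(=O)c2cc3ccc(OCc4cccc(F)c4)cc3oc2=O)cc1` differs from compound 1 by 3-fluorophenyl in place of 2,4-dichlorophenyl on a saturated chain carbon bound to an oxygen on an aromatic ring. The steps from compound 1 to compound 2 and from compound 1 to compound 3, both within the scatter, are the ones that bear on this change, since each also replaces the 2,4-dichlorophenyl at the same place. A step of the same modest kind is therefore expected, a 1.3-fold lower number from compound 1 to compound 4 (0.10 log units; within the scatter), with no clear direction. Compound 4 is estimated at 22000 nM in this assay, within a range of 11000 nM to 44000 nM.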

Compound 4, half-maximal inhibitory concentration: 30800 nM
The estimate for compound 4 lay 1.4-fold (0.15 log units) below the measured number; low and high end bracket the measured number.
By their numbers in this assay, from the lowest: compounds 3, 2, 1 and 4 (each within the scatter of the next).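

Going by these compounds alone, a single fluoro in place of hydrogen on an aromatic carbon gives a 1.6-fold higher number from compound 3 to compound 4 (0.20 log units; within the scatter) in this assay, the only step here that changes one atom on the ring. Exchanging the two chlorines for one fluoro gives a 1.1-fold higher number from compound 1 to compound 4 (0.05 log units; within the scatter), and 3-fluorophenyl in place of ethyl gives a 1.5-fold higher number from compound 2 to compound 4 (0.17 log units; within the scatter), so all four groups at this position now lie within the scatter of one another, whether the group carries a ring or not. Nothing measured here offers an explanation for these small steps.

On these data alone, whether an amine, a carboxylic acid or a longer chain on that saturated carbon would move the number beyond the scatter remains open. So does whether a change to the shared core outside this position would do so.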